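This account rests on a few compounds, and the source may have more. Where it says the series, first, only, none or still open, it means among the compounds named here.

Three compounds have been measured in a functional assay on A549 cells (Homo sapiens) for inhibition, read by MTT assay, with a stated time of 72 h; on this read-out higher numbers stand for weaker inhibition and lower numbers for stronger inhibition:

Compound 1, `C/C=C\C(=O)Nc1cc(Nc2nc3c(c(-c4cn(C)c5ccccc45)n2)CSCC3)c(OC)cc1N(C)CCN(C)C`: compound 1 gives 6860 nM
Compound 2, `CC/C=C\C(=O)Nc1cc(Nc2nc3c(c(-c4cn(C)c5ccccc45)n2)CSCC3)c(OC)cc1N(C)CCN(C)C`: compound 2 gives 236 nM
Compound 3, `CC/C=C\C(=O)Nc1cc(Nc2nc3c(c(-c4cn(C)c5ccc(F)cc45)n2)CS(=O)(=O)CC3)c(OC)cc1N(C)CCN(C)C`: compound 3 gives 5830 nM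

Compound 2 differs from compound 1 by methyl in place of hydrogen on a saturated chain carbon bound to a double-bonded chain carbon, and this single change brought a 29-fold lower number from compound 1 to compound 2 (1.46 log units; beyond the scatter). Compound 3 carries a different core from compound 1, and the difference between the two cores is not broken down here. Compound 4, `COc1cc(N(C)CCN(C)C)c(NC(=O)/C=C\C(C)C)cc1Nc1nc2c(c(-c3cn(C)c4ccc(F)cc34)n1)CS(=O)(=O)CC2`, has not yet been measured. It differs from compound 3 by methyl in place of hydrogen on a saturated chain carbon bound to a double-bonded chain carbon and a saturated chain carbon. In compound 1 the place of the change is a saturated chain carbon bound to a double-bonded chain carbon; in compound 3 it is a saturated chain carbon bound to a double-bonded chain carbon and a saturated chain carbon, so the two changes are the same kind of change, not the same. Because of a 29-fold lower number from compound 1 to compound 2 (1.46 log units; beyond the scatter), a lower number is expected for compound 4 than for compound 3, but a smaller step is estimated, a 4.9-fold lower number from compound 3 to compound 4 (0.69 log units; beyond the scatter), since the place and the core both differ. Compound 4 is estimated at 1200 nM, expected between 250 nM and 5000 nM.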

Compound 4, half-maximal inhibitory concentration: 3750 nM
Compound 4: middle estimate off by 3.1-fold (0.49 log units), on the low side; measured number inside the range.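

In this assay, the added methyl does not repeat on the core of compound 3 the large step it gave on the core of compound 1: here the result is a 1.6-fold lower number from compound 3 to compound 4 (0.19 log units; within the scatter), so no real difference can be claimed for this pair. Set side by side, the two steps clearly differ, which shows that the size of this kind of change does not carry over unchanged within this series: the same change on two cores in this assay, a 29-fold lower number (1.46 log units; beyond the scatter) from compound 1 to compound 2 and a 1.6-fold lower number (0.19 log units; within the scatter) from compound 3 to compound 4, 19-fold (1.27 log units) apart, beyond the scatter of two such steps

This does not show why, since the two pairs differ both in the core and in the place of the added methyl, and the four compounds cannot separate these two differences.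

Going by these compounds, it remains open how the 3-methylbut-1-en-1-yl chain would behave on the core of compound 1, the pairing that would help separate the role of the core from that of the place. Also open, on these data alone, is how a longer chain or an amine at this place would compare on either core.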